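The source may hold more compounds than are shown below. What is called first, only, known or untested is meant among the compounds shown, and "the series" means these compounds.

Compound 1 `Cc1cn2c(/C=N/NC(=N)N)c(-c3ccncc3)nc2s1` gives 30900 nM in a functional assay on CNS cells (Homo sapiens) for antiproliferative activity; a higher number here means a weaker inhibitor of growth, a lower number a stronger inhibitor of growth. Its only companion, compound 2 `N=C(N)N/N=C/c1c(-c2ccncc2)nc2sc(Cl)cn12`, gives 20000 nM in this assay, and a 1.5-fold lower number from compound 1 to compound 2 (0.19 log units; within the scatter), so the two numbers sit within the scatter of each other. Compound 3 `Cc1cn2c(/C=N/NC(=N)N)c(-c3ccccn3)nc2s1` differs from compound 1 by pyridin-2-yl in place of pyridin-4-yl on an aromatic carbon. Within the data shown here, no measured step touches this exchange; the single step known concerns a different position and was itself small. For compound 3 the expected change is therefore a 1.0-fold lower number from compound 1 to compound 3 (0.01 log units; within the scatter), nothing beyond the scatter. Compound 3 is estimated at 30000 nM, within 8000 nM to 100000 nM.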

Compound 3, concentration for total growth inhibition: 26900 nM
Compound 3: the middle estimate sits 1.1-fold (0.05 log units) above what was measured, and the stated range covers the measured number.
By their numbers in this assay, from the lowest: compounds 2, 3 and 1 (each within the scatter of the next).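

In this assay, among these compounds, the exchange of pyridin-4-yl for pyridin-2-yl on this aromatic carbon gives a 1.1-fold lower number from compound 1 to compound 3 (0.06 log units; within the scatter) and so offers the first reading at this position, where the two pyridine attachments cannot be told apart. No evidence is available that would account for this result. The compounds shown leave open whether a plain phenyl ring, or a pyridine ring carrying an amine or a carboxylic acid, would move the number beyond the scatter at this position. They also leave open whether the same exchange behaves alike with chloro in place of methyl.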